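A few compounds are considered here, and "the series" means these few. Any claim that something is new, unique, unknown or untested is made for them only; others in the source may bear on it.

Compound 1 `CCCCCCCN1CCC(C(=O)Nc2cc(Cl)c(N)cc2OC)CC1` gives > 10 mg/kg in a functional assay on the whole organism for antagonist activity, with Mus musculus as the target (a lower number here means that less compound is needed, a higher number that more compound is needed for the effect), which is a limit of the assay rather than a number.
Compound 2 `CCCCCCN1CCC(C(=O)Nc2cc(Cl)c(N)cc2OC)CC1` gives > 10 mg/kg in this assay, again a limit.
Compound 3 `COc1cc(N)c(Cl)cc1NC(=O)C1CCN(Cc2cccc(C)c2)CC1` gives 2.4 mg/kg in this assay.

Among the measured compounds shown here, compound 3 therefore holds the only real number of the three; the other two sit at the limit of > 10 mg/kg in this assay, at which 2 of the 3 values shown sit. The change to compound 4 `CCCN1CCC(C(=O)Nc2cc(Cl)c(N)cc2OC)CC1` is ethyl in place of 3-methylphenyl on a saturated chain carbon bound to an amine nitrogen in a ring. For the measured compounds named here, two measured steps bear on this: an at least 4.1-fold lower number from compound 1 to compound 3 (0.61 log units; beyond the scatter) and an at least 4.1-fold lower number from compound 2 to compound 3 (0.61 log units; beyond the scatter), each showing that a plain chain in that place does worse than the ring; the step that the two limits leave unreadable from compound 1 to compound 2 adds nothing readable. Compound 4 carries an even shorter plain chain, and the expected step is a 6.3-fold higher number from compound 3 to compound 4 (0.80 log units; beyond the scatter). Compound 4 is thus estimated at 15 mg/kg, within 4 mg/kg to 50 mg/kg, most likely reported only as a limit.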

Compound 4, dose for half-maximal effect: > 10 mg/kg
Compound 4 gave a limit, no number; the forecaster's own chance of this, stated with the estimate: 70%; the middle value does not contradict the limit.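

Putting propyl in place of 3-methylbenzyl on the ring amine nitrogen gives an at least 4.1-fold higher number from compound 3 to compound 4 (0.61 log units; beyond the scatter), so shortening the plain chain does not match the aryl group. Compound 4 sits at a limit, as do compound 1 and compound 2, so none of the plain chains shown gives a real number: the limit of > 10 mg/kg in this assay, at which 3 of the 4 values shown sit. The steps among these three cannot be read, and the effect of chain length stays unknown.

Going by these compounds, it remains open whether compound 3 needs an aromatic ring, any ring, or the methyl group on it. Plain benzyl or cyclohexylmethyl in this place would separate these possibilities.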